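Chloro on the benzyl ring carried into the hydroxyethyl pair

The source may report more compounds than this note shows. Statements on the series, on what has been measured and on what is new or still open speak of the compounds shown alone.

Of the compounds shown here, three on one shared core have been measured. Compound 1 `CCNc1nc(-c2ccccc2)nc2c1nnn2Cc1ccccc1` is the parent; in an assay on Cerebral cortex for displacement of a labelled ligand from adenosine receptor A1 (Bos taurus) (on this read-out higher numbers stand for weaker inhibition and lower numbers for stronger inhibition), compound 1 gives 91 nM. Compound 2 `CCNc1nc(-c2ccccc2)nc2c1nnn2Cc1ccccc1Cl` differs from compound 1 by chloro in place of hydrogen on an aromatic carbon, and in this assay compound 2 gives 463 nM, a step of a 5.1-fold higher number from compound 1 to compound 2 (0.71 log units; beyond the scatter). Compound 3 `OCCNc1nc(-c2ccccc2)nc2c1nnn2Cc1ccccc1` differs from compound 1 by hydroxy in place of hydrogen on a saturated chain carbon, two bonds along the chain from a nitrogen on an aromatic ring; in this assay compound 3 gives 38 nM, a step of a 2.4-fold lower number from compound 1 to compound 3 (0.38 log units; beyond the scatter). Compound 3 thus holds the lowest number of the three, and both of its steps to the others lie beyond the scatter.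

Compound 4 `OCCNc1nc(-c2ccccc2)nc2c1nnn2Cc1ccccc1Cl` is not yet measured. It differs from compound 3 by chloro in place of hydrogen on an aromatic carbon. Within the data shown here, this is the same change as the one from compound 1 to compound 2: the place is described in the same words for both, an aromatic carbon of a six-membered aromatic ring of carbon only, ortho to a large group. The two cores on which the change is made differ by hydroxy in place of hydrogen on a saturated chain carbon, two bonds along the chain from a nitrogen on an aromatic ring, the hydroxy being present in compound 3 and compound 4 but not in compound 1 and compound 2.

Among the measured compounds shown here, with only one earlier instance of the change, the expectation for compound 4 rests on that single step: a step of about a 5.0-fold higher number from compound 3 to compound 4 (0.70 log units; beyond the scatter) is expected, because a 5.1-fold higher number from compound 1 to compound 2 (0.71 log units; beyond the scatter) was seen on the parent pair. Compound 4 is therefore estimated at 190 nM, with a likely range from 80 nM to 450 nM.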

Compound 4, inhibition constant: 116 nM
Compound 4: the middle estimate sits 1.6-fold (0.21 log units) above what was measured; low and high end bracket the measured number.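

Chloro on the benzyl ring gives a higher number in this assay on the hydroxy-bearing core as well, a 3.1-fold higher number from compound 3 to compound 4 (0.48 log units; beyond the scatter), and this step agrees with the one on the core without the hydroxy: the same change on two cores in this assay, a 5.1-fold higher number (0.71 log units; beyond the scatter) from compound 1 to compound 2 and a 3.1-fold higher number (0.48 log units; beyond the scatter) from compound 3 to compound 4, 1.7-fold (0.22 log units) apart, within the scatter of two such steps. Read the other way, the hydroxy gives a lower number with the chloro also present, a 4.0-fold lower number from compound 2 to compound 4 (0.60 log units; beyond the scatter), and this agrees with its step on the pair without chloro: the same change on two cores in this assay, a 2.4-fold lower number (0.38 log units; beyond the scatter) from compound 1 to compound 3 and a 4.0-fold lower number (0.60 log units; beyond the scatter) from compound 2 to compound 4, 1.7-fold (0.22 log units) apart, within the scatter of two such steps. Within these four compounds the two changes therefore carry from one core to the other with no difference beyond the scatter, but this rests on a single set of four compounds in one assay, and it neither shows why either change moves the number nor predicts the outcome on any other core.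

The compounds shown leave open whether another group on the benzyl ring, such as fluoro, methoxy or trifluoromethyl, would carry across the two cores in the same way. Also open, going by these compounds, is whether the agreement would survive a longer hydroxyalkyl chain, or an amine or a carboxylic acid in place of the hydroxy.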